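The compounds below may be only part of what the source reports. "The series", "measured", "known", "first", "only" and "open" are said of these compounds alone.

Working notes on the series.

Three compounds share one core. Compound 3 `CCN1CCN(C(=S)SCCCOc2ccc3c(=O)c(-c4ccc(OC)cc4)coc3c2)CC1` gives 7080 nM in a functional assay on PC-3 cells (Homo sapiens) for inhibition, read by MTT assay, with a stated time of 48 h (on this read-out lower numbers stand for stronger inhibition and higher numbers for weaker inhibition), the lowest of the three numbers shown. Compound 1 `COc1ccc(-c2coc3cc(OCCCSC(=S)N4CCCC4)ccc3c2=O)cc1` gives 19400 nM in this assay, and compound 2 `COc1ccc(-c2coc3cc(OCCCSC(=S)N4CCN(Cc5ccccc5)CC4)ccc3c2=O)cc1` gives 14900 nM. The two steps onto compound 3 were both modest and both beyond the scatter: a 2.7-fold lower number from compound 1 to compound 3 (0.44 log units; beyond the scatter) and a 2.1-fold lower number from compound 2 to compound 3 (0.32 log units; beyond the scatter). Compound 3 is therefore set apart from both neighbours, though not by much.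

Compound 4 `COc1ccc(-c2coc3cc(OCCCSC(=S)N4CCOCC4)ccc3c2=O)cc1` is not yet measured. It differs from compound 3 in one place: morpholin-4-yl in place of 4-ethylpiperazin-1-yl on a thiocarbonyl carbon. Both measured steps concern the group on the thiocarbonyl carbon, so both bear on this change, and each showed that the 4-ethylpiperazin-1-yl group gave the lower number against a different ring or substituent there. The change to morpholin-4-yl is expected to lose some of that, so a somewhat higher number in this assay is expected for compound 4: a 1.8-fold higher number from compound 3 to compound 4 (0.26 log units; within the scatter). For compound 4 the estimate is 13000 nM, within 5000 nM to 35000 nM.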

Compound 4, half-maximal inhibitory concentration: 27400 nM
For compound 4 the middle estimate is 2.1-fold (0.32 log units) below the measured one, and the stated range covers the measured number.
By their numbers in this assay, from the lowest: compound 3; then compounds 2, 1 and 4 (each within the scatter of the next).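

The change keeps a six-membered non-aromatic ring with 2 hetero atoms on the thiocarbonyl carbon, with the same donor and acceptor counts, yet in this assay it gives a 3.9-fold higher number from compound 3 to compound 4 (0.59 log units; beyond the scatter), so those shared counts do not make the two groups equivalent here. Morpholin-4-yl and pyrrolidin-1-yl are not separated, with a 1.4-fold higher number from compound 1 to compound 4 (0.15 log units; within the scatter), which leaves compound 3 as the only compound set apart from all the others, and only modestly. No measurement at hand explains this difference.

Still open, going by these compounds, is whether 4-methylpiperazin-1-yl or an unsubstituted piperazine ring on the thiocarbonyl carbon would keep the lower number of compound 3. Also open, on these data alone, is whether the step to morpholin-4-yl would hold with a longer chain in place of the three-carbon link.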